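Aryl Swaps on the Shared Core: Toward Compound 3

A few compounds are considered here, and "the series" means these few. Any claim that something is new, unique, unknown or untested is made for them only; others in the source may bear on it.

Measured in a functional assay on NCI-H520 cells (Homo sapiens) for inhibition, read by MTT assay, with a stated time of 48 h, tested at 10 uM; on this read-out higher numbers stand for more inhibition at the one concentration tested (going by the name of the read-out) and lower numbers for less inhibition:
compound 1 `Cc1cc(F)cc(Nc2cc(NC(=O)Nc3c(Cl)cccc3Cl)ncn2)c1` gives 60.5%
compound 2 `O=C(Nc1cc(Nc2ccc(F)c(Cl)c2)ncn1)Nc1c(Cl)cccc1Cl` gives 39.5%

Compound 2 stands lowest of the two numbers. Among the compounds with values here, the only measured step, a number 21 percentage points lower from compound 1 to compound 2 (beyond the scatter), sits at the same nitrogen that is changed next. Compound 3 `CCc1ccc(Nc2cc(NC(=O)Nc3c(Cl)cccc3Cl)ncn2)cc1` differs from compound 2 by 4-ethylphenyl in place of 3-chloro-4-fluorophenyl on a nitrogen on an aromatic ring. That step shows the group on this nitrogen can move the read-out beyond the scatter, but two points give no direction for 4-ethylphenyl. Compound 3 is therefore expected near the middle of the measured numbers, at 50%, with a range from 25% to 75%. The expected step is a number 10.5 percentage points higher from compound 2 to compound 3 (beyond the scatter).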

Compound 3, a percentage reported as inhibition, at one concentration (the size of the read-out at that concentration, not a potency): 31.5%
Compound 3: middle estimate off by 18.5 percentage points, on the high side; the range from low to high includes it.
By their numbers in this assay, from the lowest: compounds 3 and 2 (each within the scatter of the next); then compound 1.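

Two different groups on this nitrogen, 3-chloro-4-fluorophenyl and 4-ethylphenyl, now give numbers that cannot be told apart (a number 8 percentage points lower from compound 2 to compound 3 (within the scatter)). Compound 1, with 3-fluoro-5-methylphenyl, stands apart from compound 3 as well (a number 29 percentage points lower from compound 1 to compound 3 (beyond the scatter)), so its gap is no longer seen against compound 2 alone. No available evidence explains the difference.

Open, on these data alone, is whether 3-fluoro-5-methylphenyl is unusual among aryl groups here or only the best of three. Also open, as far as these compounds go, is how an amine or a carboxylic acid on this phenyl ring, or a longer chain in place of ethyl, would read.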